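Triazine hydrazones: a pyridin-2-yl in place of a pyrazolyl

The compounds below may be only part of what the source reports. "The series", "measured", "known", "first", "only" and "open" are said of these compounds alone.

Measured so far:
compound 1, `NS(=O)(=O)c1ccc(Nc2nc(N/N=C/c3ccc(C(F)(F)F)cc3)nc(Nc3ccccc3)n2)cc1`, 1860 nM
compound 2, `Cc1nn(-c2ccccc2)cc1/C=N/Nc1nc(Nc2ccccc2)nc(Nc2ccc(S(N)(=O)=O)cc2)n1`, 2470 nM

In a functional assay on COLO 205 cells (Homo sapiens) for inhibition, read by sulforhodamine B assay, with a stated time of 48 h (on this read-out higher numbers stand for weaker inhibition of growth and lower numbers for stronger inhibition of growth), compound 2 gives 2470 nM, the highest of the two numbers measured; the nearest is compound 1, and the difference a 1.3-fold higher number from compound 1 to compound 2 (0.12 log units; within the scatter) does not separate them. Compound 3, `NS(=O)(=O)c1ccc(Nc2nc(N/N=C/c3ccccn3)nc(Nc3ccccc3)n2)cc1`, has not yet been measured. It differs from compound 2 in one place: pyridin-2-yl in place of 3-methyl-1-phenyl-1H-pyrazol-4-yl on a carbon with a double bond to nitrogen. For the measured compounds named here, the only measured step that bears on this position is the one from compound 1 to compound 2, a 1.3-fold higher number from compound 1 to compound 2 (0.12 log units; within the scatter), in which a larger exchange of the group on the carbon with a double bond to nitrogen left the number within the scatter. On that basis no step beyond the scatter is expected for compound 3 either, and the direction cannot be told from the two numbers available. Compound 3 is therefore estimated at 2000 nM in this assay, with a range from 700 nM to 6000 nM, which means an expected step of a 1.2-fold lower number from compound 2 to compound 3 (0.09 log units; within the scatter) from compound 2 to compound 3.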

Compound 3, concentration for 50% growth inhibition: 410 nM
Compound 3: middle estimate off by 4.9-fold (0.69 log units), on the high side; the measured number lies below the stated range.
By their numbers in this assay, from the lowest: compound 3; then compounds 1 and 2 (each within the scatter of the next).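

The group on the carbon with a double bond to nitrogen is not indifferent in this assay: pyridin-2-yl brings a 6.0-fold lower number from compound 2 to compound 3 (0.78 log units; beyond the scatter) and, set against the other group, a 4.5-fold lower number from compound 1 to compound 3 (0.66 log units; beyond the scatter) while the earlier exchange gave only a 1.3-fold higher number from compound 1 to compound 2 (0.12 log units; within the scatter) and so showed no effect of this position. The entering group is a single six-membered aromatic ring with 1 hetero atom, whereas the 3-methyl-1-phenyl-1H-pyrazol-4-yl it replaces holds a five-membered aromatic ring with 2 hetero atoms and a six-membered aromatic ring of carbon only, so the change alters ring count, size and hetero atoms together, and these compounds cannot separate them. No measurement at hand explains why the pyridin-2-yl compound gives the lower number.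

The compounds shown leave open whether the gain belongs to the ring nitrogen of pyridin-2-yl or simply to the single ring, a question that an unsubstituted phenyl or a pyridin-4-yl group on the same carbon would address. They also leave open whether a methoxy group or an amine on the pyridine ring would keep the number of compound 3 or lose it.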